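Amide aryl swap on the shared naphthyl core

The source may report more compounds than this note shows. Statements on the series, on what has been measured and on what is new or still open speak of the compounds shown alone.

Measured so far:
compound 1 `Cc1ccc(NC(=O)COc2ccc3cc(/C=C4/SC(=O)NC4=O)ccc3c2)cc1` gives 1700 nM in an assay on isolated protein for inhibition of histone deacetylase 4 (Homo sapiens), with a stated time of 1 h; a lower number here means a stronger inhibitor, a higher number a weaker inhibitor
compound 2 `O=C(COc1ccc2cc(/C=C3/SC(=O)NC3=O)ccc2c1)Nc1ccc(Cl)c(Cl)c1` gives 5500 nM in this assay

For the measured compounds named here, compound 2 holds the highest number of the two measured; its only neighbour is compound 1, separated by the step of a 3.2-fold higher number from compound 1 to compound 2 (0.51 log units; beyond the scatter). Compound 3 `Cc1cccc(NC(=O)COc2ccc3cc(/C=C4/SC(=O)NC4=O)ccc3c2)n1` differs from compound 2 by 6-methylpyridin-2-yl in place of 3,4-dichlorophenyl on an amide-type nitrogen. Going by the values given here, the single measured step that bears on this position is a 3.2-fold higher number from compound 1 to compound 2 (0.51 log units; beyond the scatter), which accompanied the arrival of the same 3,4-dichlorophenyl that now leaves. Among the compounds with values here, its removal in compound 3 is therefore expected to move the number back toward that of compound 1, but no measured compound carries a pyridinyl on this nitrogen, so the size of the return is uncertain and the range is kept wide. For compound 3 the expected step is a 2.2-fold lower number from compound 2 to compound 3 (0.34 log units; beyond the scatter). Compound 3 is estimated at 2500 nM in this assay, with a range from 1000 nM to 7000 nM.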

Compound 3, half-maximal inhibitory concentration: 1100 nM
Compound 3: middle estimate off by 2.3-fold (0.36 log units), on the high side; the measured number falls inside the stated range.
By their numbers in this assay, from the lowest: compounds 3 and 1 (each within the scatter of the next); then compound 2.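

In this assay, placing 6-methylpyridin-2-yl on the amide-type nitrogen in place of 3,4-dichlorophenyl gives a 5.0-fold lower number from compound 2 to compound 3 (0.70 log units; beyond the scatter) and so sets compound 2 apart from both other compounds by steps beyond the scatter. The comparison a 1.5-fold lower number from compound 1 to compound 3 (0.19 log units; within the scatter) does not separate 6-methylpyridin-2-yl from 4-methylphenyl, so among these three compounds only the 3,4-dichlorophenyl goes with a distinct number. Nothing at hand accounts for this difference.

Still open, as far as these compounds go, is whether the ring nitrogen or the methyl of the 6-methylpyridin-2-yl matters at this position, and whether both chlorines are needed for the higher number of compound 2. A plain phenyl, a 4-chlorophenyl or an unsubstituted pyridin-2-yl on the same nitrogen would address these questions.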